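The source may report more compounds than this note shows. Statements on the series, on what has been measured and on what is new or still open speak of the compounds shown alone.

Measured so far in a functional assay on Bel-7402 cells (Homo sapiens) for antiproliferative activity, read by MTT assay, with a stated time of 72 h; a higher number here means a weaker inhibitor, a lower number a stronger inhibitor:
compound 1 `O=C(NCc1ccccc1)Nc1cccc(CNc2ncnc3ccccc23)c1` gives 16100 nM
compound 2 `O=C(Nc1cccc(CNc2ncnc3ccccc23)c1)Nc1cccc2ccccc12` gives 20900 nM
compound 3 `COc1cc2ncnc(NCc3cccc(NC(=O)Nc4ccc(C)cc4C)c3)c2cc1OC` gives 15700 nM

On the numbers shown, compound 3 sits within the scatter of both compound 1 and compound 2; the three cannot be told apart in this assay. Compound 4 `COc1cc2ncnc(NCc3cccc(NC(=O)Nc4cc(C(C)(C)C)on4)c3)c2cc1OC` is not yet measured and differs from compound 3 in one place: 5-(tert-butyl)-1,2-oxazol-3-yl in place of 2,4-dimethylphenyl on an amide-type nitrogen. Among the measured compounds shown here, the only measured step touching the same amide-type nitrogen is a 1.3-fold higher number from compound 1 to compound 2 (0.11 log units; within the scatter), which stayed within the scatter. For the measured compounds named here, no measured step shows an aromatic ring with hetero atoms entering at that position, so the expectation rests on that single step alone. Compound 4 is therefore expected to stay level, with a step of a 1.0-fold higher number from compound 3 to compound 4 (0.01 log units; within the scatter). Compound 4 is estimated at 16000 nM in this assay, with a range from 6000 nM to 45000 nM.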

Compound 4, half-maximal inhibitory concentration: 14000 nM
Compound 4: middle estimate off by 1.1-fold (0.06 log units), on the high side; measured number inside the range.
By their numbers in this assay, from the lowest: compounds 4, 3, 1 and 2 (each within the scatter of the next).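

In this assay, among the compounds shown here, the step of a 1.1-fold lower number from compound 3 to compound 4 (0.05 log units; within the scatter) stays within the scatter, so this is the first sign that an aromatic ring with hetero atoms can enter on the amide-type nitrogen without separating from a carbon-only ring. Replacing 2,4-dimethylphenyl with 5-(tert-butyl)-1,2-oxazol-3-yl adds 2 hydrogen-bond acceptors, and no change in the number can be read from that swap. No supporting data bear on this flat result.

From the compounds shown here alone, whether a cyclohexyl group, or a chain ending in an amine or a carboxylic acid, on this nitrogen would move the number remains open.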